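The compounds below may be only part of what the source reports. "The series", "measured", "known", "first", "only" and "open" are said of these compounds alone.

Measured so far, in a functional assay on KYSE-450 cells (Homo sapiens) for inhibition, read by MTT assay, with a stated time of 48 h; a higher number here means a weaker inhibitor, a lower number a stronger inhibitor:

Compound 1, `C/C=C/C=C/C(=O)N(Cc1ccc(OC)c(O)c1)c1cc(OC)c(OC)c(OC)c1` — compound 1 gives 180 nM.
Compound 2, `COc1cc(NCc2ccccc2)cc(OC)c1OC` — compound 2 gives > 80000 nM, which is a limit of the assay and not a number.
Compound 3, `C/C=C/C(=O)N(Cc1ccc(OC)c([N+](=O)[O-])c1)c1cc(OC)c(OC)c(OC)c1` — compound 3 gives 510 nM.

Compound 1 stands lowest of the two numbers in this assay; compound 3, the nearest, lies beyond the scatter above it. Compound 2 carries no acyl group on its nitrogen at all and sits at the limit of > 80000 nM in this assay, at which 1 of the 3 values shown sits. No two of these compounds differ in only one place, so no single step has been measured within the set.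

Compound 4, `COc1ccc(CN(C(=O)CBr)c2cc(OC)c(OC)c(OC)c2)cc1O`, is the next entry. It differs from compound 1 in one place: bromomethyl in place of penta-1,3-dien-1-yl on a carbonyl carbon. The bromomethyl group that enters is smaller by three carbons than the penta-1,3-dien-1-yl group that leaves, and the two double bonds outside aromatic rings are lost with it. The acylated nitrogen itself is kept, which is what separates compounds 1 and 3 from compound 2.

Within the data shown here, with no measured step of this kind to lean on, a modest weakening is expected, within or just past the scatter, as a 3.3-fold higher number from compound 1 to compound 4 (0.52 log units; beyond the scatter). Compound 4 is therefore estimated at 600 nM in this assay, with a range from 150 nM to 3000 nM.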

Compound 4, half-maximal inhibitory concentration: 120 nM
Compound 4: the middle estimate sits 5.0-fold (0.70 log units) above what was measured; measured number below the stated range.
By their numbers in this assay, from the lowest: compounds 4 and 1 (each within the scatter of the next); then compound 3. At a limit, above all of these: compound 2.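

In this assay, the exchange of penta-1,3-dien-1-yl for bromomethyl on a carbonyl carbon gives a 1.5-fold lower number from compound 1 to compound 4 (0.18 log units; within the scatter). Among these compounds, this is the first single-place step in the set, and it shows that the two double bonds outside aromatic rings and the larger carbon chain of the leaving group are not needed at this position for a reading of this order: compound 4 gives 120 nM. The earlier compounds shown here, none a single change from another, could not show how far this position tolerates an exchange of its group.

Among the compounds shown here, only two groups can be compared in one place on this carbonyl carbon, so what a plain methyl, an aminomethyl group or a longer saturated chain would give here remains open, as does whether the bromine itself has any part in the reading of compound 4. Compound 2 has no acyl group on its nitrogen and differs from the other compounds in more than one place, so it supplies no step, and its reading is a limit of the assay and not a number: the limit of > 80000 nM in this assay, at which 1 of the 4 values shown sits.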